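The source may report more compounds than this note shows. Statements on the series, on what has been measured and on what is new or still open speak of the compounds shown alone.

Values in an ADME assay on microsomes from liver (Mus musculus) for metabolic stability, with a stated time of 10 min (on this read-out higher numbers stand for a more stable compound and lower numbers for a less stable compound), so far:
- compound 1 (`Cc1c(Cl)cccc1Oc1cccn2c(C34CCC(CC3)C4)nnc12`) gives 57%
- compound 2 (`CC(=O)N1CCC(c2nnc3c(Oc4cccc(Cl)c4C)cccn23)CC1`) gives 90%

Among the compounds with values here, compound 2 holds the highest of the two numbers, with a number 33 percentage points higher from compound 1 to compound 2 (beyond the scatter) as the only measured step, large and beyond the scatter. The change now in view leads to compound 3 (`Cc1c(Cl)cccc1Oc1cccn2c(C3CCCCCC3O)nnc12`) and puts 2-hydroxycycloheptyl in place of 1-acetylpiperidin-4-yl on an aromatic carbon. The measured step bears on this directly: there 1-acetylpiperidin-4-yl entered in place of a group with rings of carbon only, and compound 3 returns to a ring of carbon only, now with a hydroxy group. Within the data shown here, no measured compound carries that group, so the range stays wide. In this assay a sizeable downward move is expected, giving back much of the earlier gain. The expected move is a number 25 percentage points lower from compound 2 to compound 3 (beyond the scatter) as a working estimate. Compound 3 is estimated at 65% with an expected range of 40% to 87% for now.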

Compound 3, percent of the compound remaining: 43%
Compound 3: middle estimate off by 22 percentage points, on the high side, within the range that was stated.
By their numbers in this assay, from the lowest: compound 3; then compound 1; then compound 2.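

In this assay, the change to 2-hydroxycycloheptyl on this aromatic carbon gives a number 47 percentage points lower from compound 2 to compound 3 (beyond the scatter), removing more than the gain seen earlier at this position. The same group in place of the other carbon-only ring system gives a number 14 percentage points lower from compound 1 to compound 3 (beyond the scatter), so both compounds with rings of carbon only lie beyond the scatter under compound 2, and a hydroxy group on such a ring does not restore the higher number. Nothing at hand explains these differences.

The compounds shown leave open which part of 1-acetylpiperidin-4-yl goes with the high number, as the ring nitrogen, the acetyl group and the ring size all differ in these steps. A piperidine with a free amine, or plain cycloheptyl without the hydroxy group, would separate these parts.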